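Chlorine position on the phenoxy group: towards compound 4

The source may hold more compounds than are shown below. What is called first, only, known or untested is meant among the compounds shown, and "the series" means these compounds.

Measured so far in this assay:
compound 1 `NC1=NC2(CCOCC2)N(OCCCOc2cccc(Cl)c2)C(N)=N1` gives 83.2%
compound 2 `NC1=NC2(CCOCC2)N(OCCCOc2cc(Cl)c(Cl)cc2Cl)C(N)=N1` gives > 90%
compound 3 `NC1=NC2(CCOCC2)N(OCCCOc2ccc(Cl)cc2)C(N)=N1` gives > 90%

In an assay on isolated protein for inhibition of Dihydrofolate reductase (Homo sapiens), read by spectrophotometry, using NADPH, with stated times of 5 s and 6 min, tested at 5 uM (a lower number here means a weaker effect, a higher number a stronger effect of the compound at the concentration tested), compound 1 gives 83.2%. For compound 2 the value > 90% is a limit of the assay, not a number. For compound 3 the value > 90% is likewise a limit. Among the measured compounds shown here, compound 1 therefore carries the only read number in the set; the other two sit at the limit (the limit of > 90% in this assay, at which 2 of the 3 values shown sit).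

The measured steps that change the chlorophenyl group read a number at least 6.8 percentage points higher from compound 1 to compound 2 (that floor lies within the scatter) and a number at least 6.8 percentage points higher from compound 1 to compound 3 (that floor lies within the scatter). Between the two limits, a step that the two limits leave unreadable from compound 2 to compound 3.

Compound 4 `NC1=NC2(CCOCC2)N(OCCCOc2ccccc2Cl)C(N)=N1` differs from compound 1 by 2-chlorophenyl in place of 3-chlorophenyl on an oxygen on a saturated carbon. The two steps from compound 1 that bear on this change both end at the limit, and the floor they certify lies within the scatter, so they support a step upward of uncertain size, perhaps none beyond the scatter. The step from compound 1 is expected to be a number 4.8 percentage points higher from compound 1 to compound 4 (within the scatter). Compound 4 is estimated at 88%, with a range from 78% to 95%, and the assay may again report only a limit.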

Compound 4, a percentage reported as inhibition, at one concentration (the size of the read-out at that concentration, not a potency): 83.3%
Beside the measured number, compound 4's estimate is 4.7 percentage points above it; low and high end bracket the measured number.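

Among the compounds shown here, the change from 3-chlorophenoxy to 2-chlorophenoxy gives a number 0.1 percentage points higher from compound 1 to compound 4 (within the scatter), so this is the first comparison with a read number at both ends, and it separates the two chlorine placings by nothing beyond the scatter. Against the 4-chlorophenyl group, the 2-chlorophenyl group gives a number at least 6.7 percentage points lower from compound 3 to compound 4 (that floor lies within the scatter), and against the 2,4,5-trichlorophenyl group it gives a number at least 6.7 percentage points lower from compound 2 to compound 4 (that floor lies within the scatter); both floors stay inside the scatter, so neither step establishes a real loss on going to the 2-chlorophenyl group. Compound 2 and compound 3 both remain limits of the assay, not numbers, and the step between them cannot be read: the limit of > 90% in this assay, at which 2 of the 4 values shown sit.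

On these data alone, whether the 4-chlorophenyl group truly stands apart from the 2-chlorophenyl and 3-chlorophenyl groups stays open until compound 3 has a read number rather than a limit. Also open, as far as these compounds go, is how the inhibition read-out would respond to a substituent other than chlorine on the phenyl group, such as a methoxy group, an amine or a carboxylic acid, or to a longer chain between the core and the phenoxy group.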